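A Fluoro Added to the Fused Ring of Compound 2

The compounds below may be only part of what the source reports. "The series", "measured", "known", "first", "only" and "open" are said of these compounds alone.

Compound 1 `Cc1ccc(-c2ccc(F)cc2)n1-c1ccc(-c2nc3ccccc3s2)cc1` gives 4340 nM in a functional assay on MDA-MB-231 cells (Homo sapiens) for cytotoxicity, read by sulforhodamine B assay, with a stated time of 48 h; a lower number here means a stronger inhibitor of growth, a higher number a weaker inhibitor of growth. Compound 2 `COc1ccc(-c2ccc(C)n2-c2ccc(-c3nc4ccccc4s3)cc2)cc1` gives 3990 nM in this assay, and the step of a 1.1-fold lower number from compound 1 to compound 2 (0.04 log units; within the scatter) is within the scatter, so the two compounds cannot be put in order. Compound 3 `COc1ccc(-c2ccc(C)n2-c2ccc(-c3nc4ccc(F)cc4s3)cc2)cc1` differs from compound 2 by fluoro in place of hydrogen on an aromatic carbon, on the 1,3-benzothiazol-2-yl part rather than on the ring changed between compound 1 and compound 2. Among the compounds with values here, no measured step touches this position, and the only step in hand, a 1.1-fold lower number from compound 1 to compound 2 (0.04 log units; within the scatter), stayed within the scatter, so no shift beyond the scatter is expected in this assay. Compound 3 is therefore expected to give 3500 nM, with a range from 1500 nM to 8000 nM. The expected step is a 1.1-fold lower number from compound 2 to compound 3 (0.06 log units; within the scatter).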

Compound 3, concentration for 50% growth inhibition: 3070 nM
Compound 3: middle estimate off by 1.1-fold (0.06 log units), on the high side; the range from low to high includes it.
By their numbers in this assay, from the lowest: compounds 3, 2 and 1 (each within the scatter of the next).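

The fused ring now has a measured step of its own: in this assay the change from 1,3-benzothiazol-2-yl to 6-fluoro-1,3-benzothiazol-2-yl gives a 1.3-fold lower number from compound 2 to compound 3 (0.11 log units; within the scatter) and so leaves the result within the scatter. This position therefore carries a fluoro with no change that can be told apart from repeat measurements. Nothing available explains the size of this step.

On these data alone, whether an amine or a carboxylic acid at this same place would move the number beyond the scatter stays open. Fluoro is also the only group shown on this ring, so other positions on it remain unknown.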